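The source may report more compounds than this note shows. Statements on the series, on what has been measured and on what is new or still open speak of the compounds shown alone.

Measured compounds:
compound 1 `Cc1ccc(CSc2cc(Cl)c(C)cc2S(=O)(=O)/N=C(\N)n2nc(C)cc2-c2ccccc2)cc1`: 62000 nM
compound 2 `Cc1ccc(CSc2cc(Cl)c(C)cc2S(=O)(=O)/N=C(\N)n2nccc2-c2ccccc2)cc1`: 17000 nM

Both compounds were tested in a functional assay on HeLa cells (Homo sapiens) for cytotoxicity, read by MTT assay, with a stated time of 72 h; on this read-out lower numbers stand for stronger inhibition and higher numbers for weaker inhibition. Compound 1 stands highest of the two numbers; the nearest is compound 2, with a 3.6-fold lower number from compound 1 to compound 2 (0.56 log units; beyond the scatter), a change of hydrogen in place of methyl on an aromatic carbon of the shared core.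

Compound 3 `Cc1cc(-c2ccccc2)n(/C(N)=N/S(=O)(=O)c2cc(C)c(Cl)cc2SCc2ccccc2C(F)(F)F)n1` has not yet been measured. It differs from compound 1 in one place: 2-(trifluoromethyl)phenyl in place of 4-methylphenyl on a saturated chain carbon bound to a sulfur. Among the measured compounds shown here, the only measured step, that from compound 1 to compound 2, alters a different part of the shared core, so no measured step bears on this exchange, and the data give no guide to its size or direction. The expectation for compound 3 in this assay is therefore a number near that of compound 1, with no step beyond the scatter, that is a 1.0-fold lower number from compound 1 to compound 3 (0.01 log units; within the scatter). Compound 3 is estimated at 60000 nM, with a range from 15000 nM to 200000 nM.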

Compound 3, half-maximal inhibitory concentration: 215000 nM
Compound 3: middle estimate off by 3.6-fold (0.55 log units), on the low side; the measured number lies above the stated range.
By their numbers in this assay, from the lowest: compound 2; then compound 1; then compound 3.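

In this assay, the group on the saturated chain carbon bound to a sulfur proves able to move the read-out: 2-(trifluoromethyl)phenyl in place of 4-methylphenyl gives a 3.5-fold higher number from compound 1 to compound 3 (0.54 log units; beyond the scatter), a shift towards weaker inhibition. Among the compounds shown here, this runs opposite in direction to the one earlier step, a 3.6-fold lower number from compound 1 to compound 2 (0.56 log units; beyond the scatter), so a second part of the molecule now affects the number, and here the change lowers the effect. Nothing available explains the loss.

This exchange alters two things at once, since methyl gives way to trifluoromethyl and the number in the group's name goes from 4 to 2, and the compounds shown cannot separate the two. Also open, going by these compounds, is where a plain phenyl or a methoxyphenyl at this place would fall relative to compound 1 and compound 3.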